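The compounds below may be only part of what the source reports. "The series", "measured", "known", "first", "only" and "open" are said of these compounds alone.

The measured compounds are these. Compound 1 `CC1CCN(C2CCN(S(=O)(=O)c3cccc(-c4ccccc4C(F)(F)F)c3)CC2)CC1` in an ADME assay on HCT-116 cells (Homo sapiens) for cytotoxicity, read by CellTiter-Glo, with a stated time of 72 h (a higher number here means a weaker inhibitor, a lower number a stronger inhibitor), gives > 5000 nM, which is a limit of the assay and not a number. Compound 2 `CC1CCN(C2CCN(S(=O)(=O)c3cccc(Br)c3)CC2)CC1` in this assay gives > 5000 nM, again only a limit. Compound 3 `COc1ccccc1-c1cccc(S(=O)(=O)N2CCC(N3CCC(C)CC3)CC2)c1` in this assay gives > 5000 nM, once more a limit.

Among the measured compounds shown here, compound 2 therefore stands exactly where the other two stand: every value shown sits at the limit of > 5000 nM in this assay, at which 3 of the 3 values shown sit, so no compound can be ranked against another, and compound 2 has no number of its own, only a limit.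

The step to the unmeasured compound 4 `CC1CCN(C2CCN(S(=O)(=O)c3cn(C)cn3)CC2)CC1` changes the group on the sulfonyl sulfur: 1-methyl-1H-imidazol-4-yl in place of 3-bromophenyl on a sulfonyl sulfur. Three measured steps exist around compound 2, but none can be read: a step that the two limits leave unreadable from compound 1 to compound 2, a step that the two limits leave unreadable from compound 2 to compound 3 and a step that the two limits leave unreadable from compound 1 to compound 3 all run between two limits, so their sizes stay hidden. For the measured compounds named here, none of them exchanges an aromatic ring of carbon only for a five-membered ring with hetero atoms, so no measured step bears directly on this change. With every neighbour at the limit, no step beyond the scatter can be expected in this assay in either direction.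

Compound 4 is thus expected to give about 8000 nM, with a range from 3000 nM to 30000 nM. The step that the limit leaves unreadable from compound 2 to compound 4 is an expectation only, and a limit rather than a number is the most likely outcome.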

Compound 4, half-maximal inhibitory concentration: > 10000 nM
Compound 4: only a limit was reported; the forecaster's own chance of this, stated with the estimate: 85%; at least 1.2-fold (0.09 log units) between middle value and limit.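

In this assay compound 4 gives > 10000 nM, which is a limit of the assay and not a number. Compound 2 also has only a limit, and the step between compound 2 and compound 4 cannot be read. The compounds shown leave open whether any of them has a measurable half-maximal value in this assay, and how they would rank.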